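Anilide substituent removal in the rat paw edema series

The compounds below may be only part of what the source reports. "The series", "measured", "known", "first", "only" and "open" are said of these compounds alone.

Measured so far:
compound 1 `COc1ccc(-n2nc(C(=O)Nc3ccc(C(F)(F)F)cc3)nc2-c2cc(OC)c(OC)c(OC)c2)cc1` — 96%
compound 2 `COc1ccc(-n2nc(C(=O)Nc3ccc(C(=O)O)cc3)nc2-c2cc(OC)c(OC)c(OC)c2)cc1` — 109%

In a functional assay on the whole organism for inhibition, with Rattus norvegicus as the target, read by paw edema, with stated times of 30 min and 3 h, at a dose of 0.28 mmol/kg by the oral route (a lower number here means less inhibition, a higher number more inhibition at the dose given (going by the name of the read-out)), compound 2 stands highest of the two numbers; the nearest is compound 1, with the step of a number 13 percentage points higher from compound 1 to compound 2 (beyond the scatter). Compound 3 `COc1ccc(-n2nc(C(=O)Nc3ccccc3)nc2-c2cc(OC)c(OC)c(OC)c2)cc1` is not yet measured; it differs from compound 2 by hydrogen in place of carboxy on an aromatic carbon. Going by the values given here, the one measured step, a number 13 percentage points higher from compound 1 to compound 2 (beyond the scatter), concerns the same carboxy group on entering and was modest; taking that group away again is expected to lower the number by a step of similar size, a number 16 percentage points lower from compound 2 to compound 3 (beyond the scatter). Compound 3 is therefore expected to give 93%, with a range from 75% to 108%.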

Compound 3, a percentage reported as inhibition, in the whole organism at one dose (the size of the read-out at that dose, not a potency): 79%
For compound 3 the middle estimate is 14 percentage points above the measured one, within the range that was stated.
By their numbers in this assay, from the lowest: compound 3; then compound 1; then compound 2.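

With hydrogen at this place as the reference, removing either group lowers the number in this assay: a number 30 percentage points lower from compound 2 to compound 3 (beyond the scatter) for carboxy and a number 17 percentage points lower from compound 1 to compound 3 (beyond the scatter) for trifluoromethyl. Among these three compounds, both groups on this aromatic carbon therefore give more inhibition at the dose than hydrogen, and the loss is larger for carboxy. Nothing at hand explains either step. From the compounds shown here alone, whether an amine, a methoxy group or chlorine here would also lift the number above that of compound 3 stays open. So does whether carboxy would do the same elsewhere on the ring.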